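Compound 3 to compound 4: methoxy gives way to chloro

This account rests on a few compounds, and the source may have more. Where it says the series, first, only, none or still open, it means among the compounds named here.

Of the compounds shown here, three have been tested so far, and each one is read against the same scale. In an ADME assay on MDBK cells (Bos taurus) for cytotoxicity (on this read-out higher numbers stand for lower toxicity in this test and lower numbers for higher toxicity in this test), compound 1 `Fc1cccc(F)c1Cn1cccc2nc(-c3c(F)cccc3F)nc1-2` gives > 100000 nM, which is a limit of the assay and not an exact number. In this assay compound 2 `Fc1cccc(F)c1-c1nc2ccn(Cc3ccccc3)cc-2n1` gives > 100000 nM, which is also a limit. In this assay compound 3 `COc1ccccc1Cn1ccc2nc(-c3ccccc3)nc-2c1` gives > 100000 nM, and this too is a limit. Compound 3 therefore stands with the other two, at the limit of > 100000 nM in this assay, at which 3 of the 3 values shown sit.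

The next compound is compound 4 `Clc1ccccc1Cn1ccc2nc(-c3ccccc3)nc-2c1`, which has chloro in place of methoxy on an aromatic carbon, ortho to a large group, turning 2-methoxyphenyl into 2-chlorophenyl (chloro in place of methoxy on an aromatic carbon). Going by the values given here, no two measured compounds differ in only one place, so the data contain no measured step to serve as a guide. The expectation for this change rests on compound 3, whose reading of > 100000 nM is a limit. The estimated step is a number no higher from compound 3 to compound 4 (the limit leaves the size open), and no change beyond the usual scatter is expected. For compound 4 the expected value is 100000 nM, with an estimated range from 30000 nM to 200000 nM.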

Compound 4, half-maximal cytotoxic concentration: > 100000 nM
Compound 4: a limit, no number; the forecaster's own chance of this, stated with the estimate: 85%; the middle value sits exactly at the limit.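

Compound 3 and compound 4 each give only a limit in this assay, not an exact number, so no step can be read between them: the limit of > 100000 nM in this assay, at which 4 of the 4 values shown sit.

The compounds shown leave open whether chloro in place of methoxy changes this read-out at all, and whether any change to these structures would bring a compound within measurable range.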